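Amide Nitrogen Substituent Size and Maximal Response in the Bile Acid Receptor Assay

The source may hold more compounds than are shown below. What is called first, only, known or untested is meant among the compounds shown, and "the series" means these compounds.

The three measured compounds share one core and differ only at an amide-type nitrogen. Compound 1 `CC(C)c1onc(-c2c(Cl)cccc2Cl)c1COc1ccc(C(=O)Nc2cccc(C(=O)O)c2)c(Cl)c1` carries hydrogen there and, in a functional assay on HEK293 cells for agonist activity at Bile acid receptor (Homo sapiens), read by a luciferase reporter (on this read-out higher numbers stand for larger maximal responses and lower numbers for smaller maximal responses), compound 1 gives 61%. Compound 2 `CCCCN(C(=O)c1ccc(OCc2c(-c3c(Cl)cccc3Cl)noc2C(C)C)cc1Cl)c1cccc(C(=O)O)c1` carries butyl, and compound 2 gives 43%. Compound 3 `CC(C)c1onc(-c2c(Cl)cccc2Cl)c1COc1ccc(C(=O)N(C)c2cccc(C(=O)O)c2)c(Cl)c1` carries methyl, and compound 3 gives 45%. Compound 3 therefore stands second highest of the three: its gap to compound 2 is within the scatter, and only compound 1 lies beyond the scatter above it.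

Compound 4 `CC(C)c1onc(-c2c(Cl)cccc2Cl)c1COc1ccc(C(=O)N(Cc2ccccc2)c2cccc(C(=O)O)c2)c(Cl)c1` differs from compound 3 in one place: phenyl in place of hydrogen on a saturated chain carbon bound to an amide-type nitrogen.

Among the measured compounds shown here, two steps bear on this. Replacing the amide hydrogen lowered the response, a number 18 percentage points lower from compound 1 to compound 2 (beyond the scatter) and a number 16 percentage points lower from compound 1 to compound 3 (beyond the scatter), but enlarging the substituent once it was present did not: a number 2 percentage points higher from compound 2 to compound 3 (within the scatter). Since compound 4 keeps a substituent and only enlarges it, no step beyond the scatter is expected, a number 1 percentage points lower from compound 3 to compound 4 (within the scatter). Compound 4 is estimated at 44%, between 30% and 58%.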

Compound 4, largest response reached (reported as efficacy), in percent of the reference or control that the assay uses: 31%
Compound 4: the middle estimate sits 13 percentage points above what was measured, within the range that was stated.
By their numbers in this assay, from the lowest: compound 4; then compounds 2 and 3 (each within the scatter of the next); then compound 1.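

In this assay the amide-type nitrogen no longer behaves as a place where any substituent gives the same response: methyl and butyl had stayed within the scatter of each other, but phenyl in place of hydrogen on the saturated chain carbon gives a separate, lower level (a number 14 percentage points lower from compound 3 to compound 4 (beyond the scatter)), and phenyl in place of propyl does the same (a number 12 percentage points lower from compound 2 to compound 4 (beyond the scatter)). Once the amide hydrogen is replaced, the identity of the substituent therefore still counts, and the whole change from the amide hydrogen to benzyl comes to a larger loss (a number 30 percentage points lower from compound 1 to compound 4 (beyond the scatter)). Nothing available explains this drop.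

The compounds shown leave open whether cyclohexylmethyl on the amide-type nitrogen would match benzyl or butyl. They also leave open whether a benzyl bearing an amine or a carboxylic acid on its ring would raise the response again.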